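The compounds below may be only part of what the source reports. "The series", "measured", "known", "first", "only" and "open" are said of these compounds alone.

Working notes on the series. In a functional assay on CCRF-CEM cells (Homo sapiens) for antiproliferative activity, read by MTT assay, with a stated time of 3 days (on this read-out lower numbers stand for stronger inhibition and higher numbers for weaker inhibition), compound 1 `Cc1ccc(C#Cc2cn(C/C=C\CN3C(=O)c4ccccc4C3=O)c(=O)[nH]c2=O)cc1` gives 238000 nM. Compound 2 `CCCCCCCCC#Cc1cn(C/C=C\CN2C(=O)c3ccccc3C2=O)c(=O)[nH]c1=O` gives 39000 nM in this assay, the step being a 6.1-fold lower number from compound 1 to compound 2 (0.79 log units; beyond the scatter). Compound 3 `CCCCCCCCC#Cc1cn(C/C=C/CN2C(=O)c3ccccc3C2=O)c(=O)[nH]c1=O` is reported in this assay only as a limit, > 250000 nM. From compound 2 to compound 3 the change is solely one of drawn configuration, and the step of an at least 6.4-fold higher number from compound 2 to compound 3 (0.80 log units; beyond the scatter) is open-ended because of the limit of > 250000 nM in this assay, at which 1 of the 3 values shown sits; the pair is notable because of the fact that compounds 2 and 3 differ only in the configuration as drawn.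

Compound 3 therefore stands at the weak end of the three values, and its number is known only as a limit.

Compound 4 `CCCCc1ccc(C#Cc2cn(C/C=C/CN3C(=O)c4ccccc4C3=O)c(=O)[nH]c2=O)cc1` differs from compound 3 by 4-butylphenyl in place of octyl on a triple-bonded carbon. Among the compounds with values here, two measured steps bear on this. The step of a 6.1-fold lower number from compound 1 to compound 2 (0.79 log units; beyond the scatter) ran in the opposite sense, an aryl group giving way to octyl and the number falling; reversing that direction points to a higher number when 4-butylphenyl takes the place of octyl. The step of an at least 6.4-fold higher number from compound 2 to compound 3 (0.80 log units; beyond the scatter) shows that the configuration drawn in compound 3 and compound 4 already sits at the limit. Compound 4 is thus expected to show a step that the limit leaves unreadable from compound 3 to compound 4 in this assay, most probably ending again at a limit. The estimate for compound 4 in this assay is 500000 nM, with a range from 150000 nM to 1500000 nM.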

Compound 4, half-maximal inhibitory concentration: 31000 nM
The estimate for compound 4 lay 16-fold (1.21 log units) above the measured number; the measured number lies below the stated range.
By their numbers in this assay, from the lowest: compounds 4 and 2 (each within the scatter of the next); then compound 1. At a limit, above all of these: compound 3.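

With the double bond drawn E, this assay records an at least 8.0-fold lower number from compound 3 to compound 4 (0.90 log units; beyond the scatter) when 4-butylphenyl takes the place of octyl on the triple-bonded carbon, so the E drawing does not by itself hold a compound at the limit. This runs opposite to a 6.1-fold lower number from compound 1 to compound 2 (0.79 log units; beyond the scatter), where octyl took the place of 4-methylphenyl with the double bond drawn Z, so compounds 1 to 4 give no single order of aryl groups and octyl at this carbon. The true size of the new step stays open, as compound 3 is known only as a limit: the limit of > 250000 nM in this assay, at which 1 of the 4 values shown sits.

Still open, going by these compounds, is whether the Z and E drawings would differ with 4-butylphenyl on the triple-bonded carbon as they do for octyl, and whether the butyl chain on the ring, rather than the ring alone, accounts for the lower number in compound 4. A decyl chain or a 4-aminophenyl group at this carbon would test how far the present results extend.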